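The compounds below may be only part of what the source reports. "The series", "measured", "known", "first", "only" and "open" are said of these compounds alone.

Measured in a physicochemical assay for solubility, read by LC-MS, in phosphate buffer, with a stated time of 24 h, at pH 7.4; a higher number here means a more soluble compound, a lower number a less soluble compound:

- Compound 1 `O=C(Nc1ccccc1)c1cnc(NCc2c(F)ccc3c2CCO3)n2cnnc12`: < 1000 nM, a limit
- Compound 2 `CN(c1ccccc1)c1cnc(NCc2c(F)ccc3c2CCO3)n2cnnc12`: < 2000 nM, a limit
- Compound 3 `O=C(Nc1cnc(NCc2c(F)ccc3c2CCO3)n2cnnc12)c1cccnc1`: 12000 nM, a number

Going by the values given here, compound 3 carries the only true number of the three and stands highest, with both other values being limits.

Compound 4 `Fc1ccc2c(c1CNc1ncc(Nc3ccccc3)c3nncn13)CCO2` is the next to be read. Its difference from compound 3 is phenyl in place of (pyridin-3-yl)carbonyl on a nitrogen on an aromatic ring. In words, this is phenyl in place of (pyridin-3-yl)carbonyl on a nitrogen on an aromatic ring, or ((pyridin-3-yl)carbonyl)amino to anilino.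

Among the compounds with values here, two measured steps bear on this change: an at least 12-fold higher number from compound 1 to compound 3 (1.07 log units; beyond the scatter) and an at least 6.0-fold higher number from compound 2 to compound 3 (0.77 log units; beyond the scatter). The first is large and the second at least modest. Both end at the ((pyridin-3-yl)carbonyl)amino group and start from a group that carries phenyl, as anilino does. Losing that group is therefore expected to bring a sizeable drop in this assay.

The expected step is an 8.0-fold lower number from compound 3 to compound 4 (0.90 log units; beyond the scatter). For compound 4 the estimated value is 1500 nM, with an expected range from 400 nM to 5000 nM. A limit instead of a number would be no surprise.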

Compound 4, solubility: 3000 nM
Compound 4: the middle estimate sits 2.0-fold (0.30 log units) below what was measured; measured number inside the range.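

In this assay, the anilino group of compound 4 keeps a true number, which neither earlier phenyl-bearing compound gave, though it stands under the ((pyridin-3-yl)carbonyl)amino group with a 4.0-fold lower number from compound 3 to compound 4 (0.60 log units; beyond the scatter). Set against phenylcarbamoyl, anilino gives an at least 3.0-fold higher number from compound 1 to compound 4 (0.47 log units; beyond the scatter), and the start of this step, compound 1, is a limit. Hydrogen in place of methyl on the nitrogen gives an at least 1.5-fold higher number from compound 2 to compound 4 (0.17 log units; that floor lies within the scatter); the start of this step, compound 2, is also a limit, and this floor alone does not separate hydrogen from methyl.

No measured property shown here accounts for these steps. Still open, from the compounds shown here alone, is whether the higher number of compound 3 follows the carbonyl or the pyridine nitrogen: a benzoylamino group or a pyridin-3-yl group on that nitrogen would separate the two, and a morpholine or a carboxylic acid at this place remains unread.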